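Swapping halogens on the aryl hydrazone of compound 3

The compounds below may be only part of what the source reports. "The series", "measured", "known", "first", "only" and "open" are said of these compounds alone.

Measured so far:
compound 1 `CN(C)CCn1cnnc1-c1cc(Oc2ccc(NC(=O)N/N=C/c3ccc(Cl)cc3)cc2F)ccn1`, 530 nM
compound 2 `CN(C)CCn1cnnc1-c1cc(Oc2ccc(NC(=O)N/N=C/c3c[nH]c4ccccc34)cc2F)ccn1`, 1300 nM
compound 3 `CN(C)CCn1cnnc1-c1cc(Oc2ccc(NC(=O)N/N=C/c3c(Cl)cccc3Cl)cc2F)ccn1`, 280 nM

In a functional assay on HT-29 cells (Homo sapiens) for cytotoxicity, read by MTT assay, with a stated time of 72 h (a lower number here means a stronger inhibitor, a higher number a weaker inhibitor), compound 3 gives the lowest number of the three, yet a 1.9-fold lower number from compound 1 to compound 3 (0.28 log units; within the scatter), so compound 1 and compound 3 cannot be told apart, while a 4.6-fold lower number from compound 2 to compound 3 (0.67 log units; beyond the scatter) sets compound 2 apart. Compound 4 `CN(C)CCn1cnnc1-c1cc(Oc2ccc(NC(=O)N/N=C/c3ccc(F)cc3F)cc2F)ccn1` is now considered. The change from compound 3 is 2,4-difluorophenyl in place of 2,6-dichlorophenyl on a carbon with a double bond to nitrogen. Among the compounds with values here, the only step that bears on it is the one between two substituted phenyl groups, a 1.9-fold lower number from compound 1 to compound 3 (0.28 log units; within the scatter), which stayed within the scatter. Compound 4 is therefore expected to show no step beyond the scatter, with the estimated step being a 1.4-fold higher number from compound 3 to compound 4 (0.15 log units; within the scatter). For compound 4 the estimated value in this assay is 400 nM, within 150 nM to 1000 nM.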

Compound 4, half-maximal inhibitory concentration: 960 nM
Compound 4: the middle estimate sits 2.4-fold (0.38 log units) below what was measured; measured number inside the range.
By their numbers in this assay, from the lowest: compounds 3, 1, 4 and 2 (each within the scatter of the next, the first and the last beyond it).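

In this assay, this position does distinguish two halogenated phenyl groups: 2,4-difluorophenyl in place of 2,6-dichlorophenyl gives a step beyond the scatter (a 3.4-fold higher number from compound 3 to compound 4 (0.54 log units; beyond the scatter)), unlike the earlier step between phenyl groups. Compound 4 still cannot be told apart from the 4-chlorophenyl compound (a 1.8-fold higher number from compound 1 to compound 4 (0.26 log units; within the scatter)) or the 1H-indol-3-yl compound (a 1.4-fold lower number from compound 2 to compound 4 (0.13 log units; within the scatter)). No measurement here accounts for the step.

From the compounds shown here alone, the two groups differ in both halogen and placement, so which of these matters remains open. A phenyl carrying an amine or a methoxy group would show whether a halogen is needed at all.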